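The compounds below may be only part of what the source reports. "The series", "measured", "known", "first", "only" and "open" are said of these compounds alone.

Measured so far in a physicochemical assay for solubility, measured as thermodynamic solubility, at pH 6.8; a higher number here means a more soluble compound, a lower number a less soluble compound:
compound 1 `CC(C)(C)OC(=O)N1Cc2ccc(/C=C/C(=O)NO)cc2C1` gives 99000 nM
compound 2 `O=C(/C=C/c1ccc2c(c1)CN(S(=O)(=O)c1cccs1)C2)NO` gives 34000 nM

Compound 1 holds the higher of the two numbers in this assay and the gap down to compound 2 lies beyond the usual scatter. Still unmeasured is compound 3 `O=C(/C=C/c1ccc2c(c1)CN(Cc1ccccc1)C2)NO` on the same core. It differs from compound 1 by benzyl in place of tert-butoxycarbonyl on an amine nitrogen in a ring. Going by the values given here, no measured step covers this change, so its size cannot be read from the data and the direction is a judgement with wide uncertainty. The starting point for the expectation is compound 1 at 99000 nM as the reference number. A small rise in this assay is expected, and a result with no change beyond the scatter would be equally unsurprising. The expected change is a 1.3-fold higher number from compound 1 to compound 3 (0.12 log units; within the scatter) as a rough estimate only. For compound 3 the estimated value is 130000 nM with an expected range from 35000 nM to 450000 nM pending measurement.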

Compound 3, solubility: 106000 nM
Compound 3: middle estimate off by 1.2-fold (0.09 log units), on the high side, and the stated range covers the measured number.
By their numbers in this assay, from the lowest: compound 2; then compounds 1 and 3 (each within the scatter of the next).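

In this assay, benzyl in place of tert-butoxycarbonyl on an amine nitrogen in a ring gives a 1.1-fold higher number from compound 1 to compound 3 (0.03 log units; within the scatter), the first step read at this position, and it stays within the scatter. The two groups differ in what is counted: tert-butoxycarbonyl has 2 hydrogen-bond acceptors and no ring, while benzyl has 0 hydrogen-bond acceptors and one six-membered aromatic ring of carbon only, yet this exchange on the shared core produces no readable difference in the number. Nothing available explains this outcome.

On these data alone, what an amine or a carboxylic acid at the end of a longer chain on this same nitrogen would do to the number remains open. As far as these compounds go, with a single step at this position, it is also open whether the exchange would stay within the scatter on any other core.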